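The source may report more compounds than this note shows. Statements on the series, on what has been measured and on what is new or still open speak of the compounds shown alone.

Working notes on the series.

Compound 1 `O=c1ccoc(/C=C/c2ccccc2)c1` and compound 2 `COc1ccc(/C=C/c2cc(=O)cco2)cc1` share a core; compound 3 `COc1ccc(/C=C/C2CC=CC(=O)O2)cc1` and compound 4 `COc1ccc(/C=C/C2CC=CC(=O)O2)c(OC)c1` share another. How the core of compound 1 and the core of compound 3 differ is not broken down here.

In a functional assay on NCI/ADR cells (Homo sapiens) for inhibition, read by sulforhodamine B assay, with a stated time of 48 h (a higher number here means a weaker inhibitor of growth, a lower number a stronger inhibitor of growth), compound 1 gives 514 uM. Compound 2 differs from compound 1 by methoxy in place of hydrogen on an aromatic carbon, and in this assay compound 2 gives 310 uM. The step of a 1.7-fold lower number from compound 1 to compound 2 (0.22 log units; within the scatter) is within the scatter, so the two numbers are not told apart.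

In this assay compound 3 gives 17.3 uM, the lowest of the three measured numbers, with both other compounds beyond the scatter from it.

Compound 4 differs from compound 3 by methoxy in place of hydrogen on an aromatic carbon. This is the same kind of change as from compound 1 to compound 2, but not the same: in the earlier pair the entering methoxy sits para to a group of 9 heavy atoms, whereas here it sits ortho to a group of 9 heavy atoms and meta to a methoxy group. The change occurs twice among the compounds shown, once measured.

For compound 4 in this assay the expected step is a 1.4-fold lower number from compound 3 to compound 4 (0.16 log units; within the scatter), set beside a 1.7-fold lower number from compound 1 to compound 2 (0.22 log units; within the scatter); it rests only on that one measured step, which was within the scatter, so a step within the scatter is expected again. The estimate for compound 4 is 12 uM, with a range from 4 uM to 40 uM.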

Compound 4, concentration for growth inhibition (reported as GI): 8.8 uM
Beside the measured number, compound 4's estimate is 1.4-fold (0.13 log units) above it; the measured number falls inside the stated range.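

In this assay, methoxy in place of hydrogen on an aromatic carbon gives a 2.0-fold lower number from compound 3 to compound 4 (0.29 log units; within the scatter), so on this second core the step again stays within the scatter. Set side by side, the steps on the two cores are not told apart: the same change on two cores in this assay, a 1.7-fold lower number (0.22 log units; within the scatter) from compound 1 to compound 2 and a 2.0-fold lower number (0.29 log units; within the scatter) from compound 3 to compound 4, 1.2-fold (0.07 log units) apart, within the scatter of two such steps. For the compounds shown here, this gives no sign that the size of the step depends on the core, but it does not show that the change carries over in general: each step is small enough that neither shows a real shift in the number, the entering methoxy sits in a different place in each pair, and only two pairs are at hand.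

The compounds shown leave open whether any other group on the same aromatic carbon, such as a hydroxyl, a chlorine atom, an amine or a longer chain like ethoxy, would give a step beyond the scatter on either core. They also leave open how much of the spread in numbers across the series belongs to the core itself, as the difference between the core of compound 1 and the core of compound 3 is not broken down here.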